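A few compounds are considered here, and "the series" means these few. Any claim that something is new, unique, unknown or untested is made for them only; others in the source may bear on it.

Measured compounds:
compound 1, `O=C(Nc1ccc2nc(NC(=O)C3CCCCC3)sc2c1)c1cccc(Oc2ccccc2)c1`: > 4 ug/mL
compound 2, `O=C(Nc1ccc2nc(NC(=O)C3CCCCC3)sc2c1)c1c(Cl)cccc1Cl`: 0.015 ug/mL
compound 3, `O=C(Nc1ccc2nc(NC(=O)C3CCCCC3)sc2c1)c1c(F)cccc1C(F)(F)F`: 0.032 ug/mL

Three amides built on the shared core have been tested in a functional assay on WI-38 VA13 cells (Homo sapiens) for cytotoxicity; a lower number here means that less compound is needed, a higher number that more compound is needed for the effect. For compound 1 the result is only a limit, > 4 ug/mL, and not a number (the limit of > 4 ug/mL in this assay, at which 1 of the 3 values shown sits). Compound 2 gives 0.015 ug/mL in this assay, the lowest of the two numbers recorded. Compound 3 gives 0.032 ug/mL in this assay, a higher number than that of compound 2 by a margin beyond the usual scatter. No two of the measured compounds differ in a single place, so no measured step can be read off.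

Compound 4, `Cc1cc(C(=O)Nc2ccc3nc(NC(=O)C4CCCCC4)sc3c2)c(C)n1C`, has not yet been measured. It differs from compound 2 in one place: 1,2,5-trimethyl-1H-pyrrol-3-yl in place of 2,6-dichlorophenyl on a carbonyl carbon. Both numbered results so far come from an amide of one six-membered aromatic ring of carbon only; compound 4 instead carries one five-membered aromatic ring with 1 hetero atom. Compound 4 is estimated to give 0.3 ug/mL in this assay, with a range from 0.05 ug/mL to 2 ug/mL. The step of a 20-fold higher number from compound 2 to compound 4 (1.30 log units; beyond the scatter) that this estimate means is expected to run toward a higher number, beyond the scatter.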

Compound 4, half-maximal effective concentration: > 6.2 ug/mL
Compound 4 was reported as a limit (the forecaster's own chance of this, stated with the estimate: 15%); at least 20-fold (1.31 log units) between middle value and limit.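

In this assay, for the compounds shown here, the exchange of 2,6-dichlorophenyl for 1,2,5-trimethyl-1H-pyrrol-3-yl on the carbonyl carbon gives the first single-place step in this set, and a large one: an at least 410-fold higher number from compound 2 to compound 4 (2.61 log units; beyond the scatter). As far as these compounds go, the result for compound 4 is a limit and not a number, so the full size of this step stays unknown: the limit of > 6.2 ug/mL in this assay, at which 1 of the 4 values shown sits. Nothing measured here gives a cause for the step, although the entering and leaving groups have the same count of heavy atoms.

The compounds shown leave open whether the step follows from the change of ring itself or from the methyl groups on the pyrrole. An unsubstituted pyrrole, a thiophene or a furan on the same carbonyl carbon would separate these two readings.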